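Iodo on the phenyl group of compound 2

The source may report more compounds than this note shows. Statements on the series, on what has been measured and on what is new or still open speak of the compounds shown alone.

compound 1 `CCCC1=C(OC)C(CCC)(CCC)C(=O)/C(=C(O)\C=C\c2ccc(I)cc2)C1=O` gives 2.4 uM here
compound 2 `CCCOC1=C(CCC)C(=O)/C(=C(O)/C=C/c2ccccc2)C(=O)C1(CCC)CCC` gives 8.3 uM here

In a functional assay on HepG2 cells (Homo sapiens) for antiproliferative activity, read by sulforhodamine B assay, with a stated time of 3 days (on this read-out lower numbers stand for an effect already at smaller amounts and higher numbers for an effect only at larger amounts of compound), compound 2 gives 8.3 uM and holds the higher of the two numbers. Compound 1 gives 2.4 uM in the same read-out, and the gap between the two lies beyond the scatter. Compound 3 `CCCOC1=C(CCC)C(=O)/C(=C(O)/C=C/c2ccc(I)cc2)C(=O)C1(CCC)CCC` is compound 2 with iodo in place of hydrogen on an aromatic carbon, para to a large group, so that phenyl becomes 4-iodophenyl (iodo in place of hydrogen on an aromatic carbon). Among the measured compounds shown here, no measured pair isolates this change. Compound 1 carries the same 2-(4-iodophenyl)ethenyl group, but its core differs from that of compound 2, so the support from compound 1 at 2.4 uM is only indirect. The estimate is a 2.4-fold lower number from compound 2 to compound 3 (0.38 log units; beyond the scatter) in this assay and points to a lower number, modestly beyond the scatter. Compound 3 is expected at 3.5 uM in a range from 1.3 uM to 9 uM as estimated.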

Compound 3, concentration for half-maximal effect: 7.3 uM
Compound 3: the middle estimate sits 2.1-fold (0.32 log units) below what was measured, within the range that was stated.
By their numbers in this assay, from the lowest: compound 1; then compounds 3 and 2 (each within the scatter of the next).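

In this assay, iodo in place of hydrogen on an aromatic carbon, para to a large group, gives a 1.1-fold lower number from compound 2 to compound 3 (0.06 log units; within the scatter), so on this core 4-iodophenyl and phenyl cannot be told apart. With 2-(4-iodophenyl)ethenyl common to both compounds, ethyl in place of hydrogen on a saturated chain carbon bound to an oxygen on an unsaturated carbon gives a 3.0-fold higher number from compound 1 to compound 3 (0.48 log units; beyond the scatter), a modest step beyond the scatter, so the gap to compound 1 lies at that oxygen-bound chain and not at the iodo. No measurement shown here accounts for either step.

As far as these compounds go, whether the chain step at the oxygen holds with plain phenyl in place of 4-iodophenyl stays open. Also open, from the compounds shown here alone, is how an amine or a carboxylic acid at the iodo position, or a longer chain on that oxygen, would read.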